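Phenoxyphenyl series: aryl change on the ring nitrogen

The source may hold more compounds than are shown below. What is called first, only, known or untested is meant among the compounds shown, and "the series" means these compounds.

Three compounds sharing one core have numbers in an assay on isolated protein for agonist activity at Bile acid receptor (Homo sapiens), read by AlphaScreen, with a stated time of 30 min (a lower number here means that less compound is needed, a higher number that more compound is needed for the effect), so far. Compound 1 `COc1ccccc1-n1nc(C)c2c1NC(=O)[C@H](C)S[C@@H]2c1ccc(Oc2ccccc2)cc1` gives 3300 nM; compound 2 `CCCc1ccccc1-n1nc(C)c2c1NC(=O)[C@H](C)S[C@@H]2c1ccc(Oc2ccccc2)cc1` gives 1100 nM; compound 3 `CCOc1cccc(-c2ccc([C@H]3S[C@@H](C)C(=O)Nc4c3c(C)nn4-c3ccccc3C)cc2)c1` gives 3500 nM. Compound 2 holds the lowest number of the three; the gap to compound 1 and the gap to compound 3 are each beyond the scatter. Among the compounds with values here, the single one-place step so far is a 3.0-fold lower number from compound 1 to compound 2 (0.48 log units; beyond the scatter).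

Compound 4 `Cc1cccc(-n2nc(C)c3c2NC(=O)[C@H](C)S[C@@H]3c2ccc(Oc3ccccc3)cc2)c1` is the next one awaiting a number. Against compound 2 the change is 3-methylphenyl in place of 2-propylphenyl on an aromatic nitrogen. Within the data shown here, no measured step covers this exchange. Compound 3 carries a 2-methylphenyl on that nitrogen, but it differs from compound 2 in a second place as well, so its number can only show that a smaller aryl there, in combination with another change, sits at a higher number than compound 2. Among the measured compounds shown here, the one step available, from compound 1 to compound 2, went toward a lower number when a larger group was put on that aryl; compound 4 moves the other way in size. A modest rise in this assay is expected for compound 4, of about a 2.3-fold higher number from compound 2 to compound 4 (0.36 log units; beyond the scatter), with the estimate for compound 4 at 2500 nM and a range from 900 nM to 7000 nM.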

Compound 4, half-maximal effective concentration: 2400 nM
Estimate against measurement, compound 4: 1.0-fold (0.02 log units) above, within the range that was stated.
By their numbers in this assay, from the lowest: compound 2; then compounds 4, 1 and 3 (each within the scatter of the next).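

In this assay the aryl on the aromatic nitrogen can now be read in a second direction: 3-methylphenyl in place of 2-propylphenyl gives (a 2.2-fold higher number from compound 2 to compound 4 (0.34 log units; beyond the scatter)), so the drop seen earlier with propyl is joined by a rise when that group leaves. The other new comparison, 3-methylphenyl in place of 2-methoxyphenyl (a 1.4-fold lower number from compound 1 to compound 4 (0.14 log units; within the scatter)), lies within the scatter, so these two aryl groups cannot be told apart at this position. Among the three compounds that differ only in this aryl, compound 2 alone separates from the other two, and its 2-propylphenyl is the largest of the three groups by heavy atoms, though three compounds make a narrow basis for any trend.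

The exchange from compound 2 to compound 4 alters both the chain and where it sits on the aryl, which leaves open whether a propyl placed where the methyl of 3-methylphenyl sits would keep the lower number, and whether an ethyl or butyl chain in place of the propyl of 2-propylphenyl would go lower or higher. No measurement at hand offers an explanation for these differences.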